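The compounds below may be only part of what the source reports. "The series", "measured", "known", "first", "only" and "open" are said of these compounds alone.

Among the measured compounds shown here, compound 2 `O=C(CCC(=O)OCCCCCCSc1ccc([N+](=O)[O-])c2nonc12)Nc1ccc(F)cc1` gives 8570 nM in an assay on isolated protein for inhibition of glutathione S-transferase P (Homo sapiens), with a stated time of 10 min (on this read-out higher numbers stand for weaker inhibition and lower numbers for stronger inhibition), and stands lowest of the three numbers measured so far, though only by margins within the scatter: compound 3 `CCN(CC)CCCNC(=O)CCC(=O)OCCCCCCSc1ccc([N+](=O)[O-])c2nonc12` gives 9550 nM and compound 1 `O=C(CCC(=O)OCCCCCCSc1ccc([N+](=O)[O-])c2nonc12)Nc1ccccc1` gives 10200 nM. The step of a 1.1-fold higher number from compound 2 to compound 3 (0.05 log units; within the scatter) and the step of a 1.1-fold lower number from compound 1 to compound 3 (0.03 log units; within the scatter) show that exchanging the group on the amide-type nitrogen, aryl for an aminoalkyl chain, left this assay unmoved, and the step of a 1.2-fold lower number from compound 1 to compound 2 (0.08 log units; within the scatter) shows the same for fluoro in place of hydrogen on the aromatic carbon.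

Compound 4 `O=C(CCC(=O)N1CCCCC1)OCCCCCCSc1ccc([N+](=O)[O-])c2nonc12` differs from compound 2 in one place: piperidin-1-yl in place of (4-fluorophenyl)amino on a carbonyl carbon. The measured steps bear on this change only in part. They cover replacement of the substituent on the amide nitrogen while the amide hydrogen was kept, and none of them removes that hydrogen-bond donor as compound 4 does. On the evidence of compound 3, whose value 9550 nM sits with the others, the step of a 1.1-fold higher number from compound 2 to compound 4 (0.04 log units; within the scatter) is expected to stay within the scatter rather than go clearly in either direction. For the measured compounds named here, compound 4 is therefore estimated at 9500 nM, with a range from 4000 nM to 25000 nM, the range widened because no measured compound lacks the amide hydrogen.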

Compound 4, half-maximal inhibitory concentration: 500 nM
Beside the measured number, compound 4's estimate is 19-fold (1.28 log units) above it; the whole stated range lies above it.
By their numbers in this assay, from the lowest: compound 4; then compounds 2, 3 and 1 (each within the scatter of the next).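

The group on this carbonyl carbon, which looked silent while only groups bearing the amide hydrogen were exchanged, turns out to matter strongly in this assay: the change gives a 17-fold lower number from compound 2 to compound 4 (1.23 log units; beyond the scatter) and, measured against the other two amides, a 19-fold lower number from compound 3 to compound 4 (1.28 log units; beyond the scatter) and a 20-fold lower number from compound 1 to compound 4 (1.31 log units; beyond the scatter). The three steps agree in direction and size, so the gain in inhibition does not depend on which of the three groups piperidin-1-yl replaces, and among these four compounds only compound 4 lacks the amide hydrogen and carries a non-aromatic ring on this carbonyl carbon. Nothing measured here accounts for the gain.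

These compounds cannot tell whether losing the amide hydrogen or gaining the piperidine ring produces the effect, since the two changes arrive together in compound 4. Cyclohexylamino, which keeps the amide hydrogen alongside a saturated ring, and diethylamino, which has no amide hydrogen and no ring, would pull the two apart, while morpholin-4-yl or pyrrolidin-1-yl would show how much the ring itself can vary.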